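The source may hold more compounds than are shown below. What is called first, only, known or untested is meant among the compounds shown, and "the series" means these compounds.

Compound 1 `Cc1nc(NCc2ccco2)c2cnn(-c3ccccc3)c2n1` is the firmer anchor: in a functional assay on G-361 cells (Homo sapiens) for cytotoxicity, read by sulforhodamine B assay (a lower number here means a stronger inhibitor of growth, a higher number a weaker inhibitor of growth), compound 1 gives 39000 nM. Compound 2 `Cc1nc(Nc2ccccc2)c2cnn(-c3ccccc3)c2n1` reached only a limit, giving > 100000 nM in this assay. That gives an at least 2.5-fold higher number from compound 1 to compound 2 (0.40 log units; beyond the scatter), with compound 2 resting at the limit of > 100000 nM in this assay, at which 1 of the 2 values shown sits, so the true gap may be wider. Compound 3 `CCNc1nc(C)nc2c1cnn2-c1ccccc1` alters compound 2 by ethyl in place of phenyl on a nitrogen on an aromatic ring. For the measured compounds named here, no measured step covers this swap, since the single step recorded concerns a different group, so the direction stays open. Compound 3 is therefore expected near 80000 nM, between 25000 nM and 300000 nM. That would amount to an expected at least 1.2-fold lower number from compound 2 to compound 3 (0.09 log units; that floor lies within the scatter).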

Compound 3, concentration for 50% growth inhibition: 38700 nM
For compound 3 the middle estimate is 2.1-fold (0.32 log units) above the measured one; measured number inside the range.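

Swapping anilino for ethylamino in this assay gives an at least 2.5-fold lower number from compound 2 to compound 3 (0.41 log units; beyond the scatter). Compound 2 stands at a limit, so this step gives only a floor: the limit of > 100000 nM in this assay, at which 1 of the 3 values shown sits. Methyl in place of furan-2-yl on the saturated chain carbon gives a 1.0-fold lower number from compound 1 to compound 3 (0.00 log units; within the scatter), so these two side chains cannot be told apart here, while phenyl directly on the nitrogen stands apart from both. On these data alone, whether a longer chain such as butyl, or a saturated ring such as cyclohexyl, on this nitrogen would read like ethyl or like phenyl stays open.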